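From ethoxy to dimethylcarbamoyl on the ring carbon

This account rests on a few compounds, and the source may have more. Where it says the series, first, only, none or still open, it means among the compounds named here.

Compound 1 `COC1(c2cc(F)cc(OCc3ccc(-n4ccnc4C)cc3)c2)CCOCC1`: 2 mg/kg
Compound 2 `CCOC1(c2cc(F)cc(OCc3ccc(-n4ccnc4C)cc3)c2)CCOCC1`: 5 mg/kg

Within the data shown here, in a functional assay on the whole organism for activation, with Mus musculus as the target (a higher number here means that more compound is needed for the effect, a lower number that less compound is needed), compound 2 gives 5 mg/kg and so holds the higher of the two numbers measured so far. Compound 3 `Cc1nccn1-c1ccc(COc2cc(F)cc(C3(C(=O)N(C)C)CCOCC3)c2)cc1` has not yet been measured. It has dimethylcarbamoyl in place of ethoxy on a saturated ring carbon and is otherwise the same as compound 2. Among the measured compounds shown here, only one measured step bears on this change: a 2.5-fold higher number from compound 1 to compound 2 (0.40 log units; beyond the scatter) comes from methyl in place of hydrogen on a saturated chain carbon bound to an oxygen on a saturated carbon. That step is modest and altered the ethoxy group itself, but it offers no direct measurement of a group with a carbonyl. A small further rise in the number is the likeliest outcome, although a single step makes this uncertain. The expected size of the change is a 1.6-fold higher number from compound 2 to compound 3 (0.20 log units; within the scatter) by this estimate. For compound 3 the estimated value is 8 mg/kg (expected range 2 mg/kg to 30 mg/kg).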

Compound 3, dose for half-maximal effect: > 20 mg/kg
Compound 3: no number, only a limit; the forecaster's own chance of this, stated with the estimate: 10%; middle value at least 2.5-fold (0.39 log units) from the limit.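

In this assay compound 3 gives > 20 mg/kg, which is a limit of the assay and not a number. Even so, the change on this saturated ring carbon can be read as an at least 4.0-fold higher number from compound 2 to compound 3 (0.60 log units; beyond the scatter), and as an at least 10-fold higher number from compound 1 to compound 3 (1.00 log units; beyond the scatter). The earlier pair had varied only the ether chain on this carbon, whereas this result shows that the carbon is not indifferent to what it carries: methoxy and ethoxy both gave measured numbers, dimethylcarbamoyl gives only a limit, and the counts of hydrogen-bond donors and acceptors are the same on both sides of the change, so those counts do not separate the two groups.

As far as these compounds go, the true number for compound 3 stays unknown, which leaves the full size of both steps open: the limit of > 20 mg/kg in this assay, at which 1 of the 3 values shown sits. Also open, from the compounds shown here alone, is whether the rise follows the carbonyl, the two methyl groups on the nitrogen or the larger count of heavy atoms, a question that a primary amide, an amine or a methoxymethyl chain on the same carbon could help to settle.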